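This account rests on a few compounds, and the source may have more. Where it says the series, first, only, none or still open, it means among the compounds named here.

Measured so far:
compound 1 `COc1cc2c(Oc3ccc(NC(=O)c4cn(-c5ccccc5C)nn4)cc3F)ccnc2cc1OCCCN1CCCCC1` — 1340 nM
compound 2 `COc1cc2c(Oc3ccc(NC(=O)c4cn(-c5c(Cl)cccc5Cl)nn4)cc3F)ccnc2cc1OCCCN1CCCCC1` — 240 nM

For the measured compounds named here, in a functional assay on HT-29 cells (Homo sapiens) for cytotoxicity, read by MTT assay, with a stated time of 72 h (on this read-out higher numbers stand for weaker inhibition and lower numbers for stronger inhibition), compound 2 gives the lower of the two numbers and compound 1 gives the higher one; the one step recorded, a 5.6-fold lower number from compound 1 to compound 2 (0.75 log units; beyond the scatter), is beyond the scatter. Compound 3 `COc1cc2c(Oc3ccc(NC(=O)c4cn(-c5ccc(F)c(F)c5)nn4)cc3F)ccnc2cc1OCCCN1CCCCC1` has not been measured. It differs from compound 2 by 3,4-difluorophenyl in place of 2,6-dichlorophenyl on an aromatic nitrogen: the group that leaves and the group that enters are counted alike in heavy atoms, donors and acceptors, and only the halogen type and the positions on the phenyl change. Going by the values given here, the single measured step concerns a change at the same phenyl, but it does not contain this pair of groups, so its direction cannot simply be carried over. With one step to go on, the expectation is a number for compound 3 that falls between the values of compound 1 and compound 2, an expected 2.9-fold higher number from compound 2 to compound 3 (0.46 log units; beyond the scatter), with wide uncertainty. The estimate for compound 3 in this assay is 700 nM, range 200 nM to 2500 nM.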

Compound 3, half-maximal inhibitory concentration: 210 nM
Beside the measured number, compound 3's estimate is 3.3-fold (0.52 log units) above it; the measured number falls inside the stated range.
By their numbers in this assay, from the lowest: compounds 3 and 2 (each within the scatter of the next); then compound 1.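

In this assay, 3,4-difluorophenyl in place of 2,6-dichlorophenyl on the aromatic nitrogen gives a 1.1-fold lower number from compound 2 to compound 3 (0.06 log units; within the scatter), so these two groups cannot be told apart here, although both the halogen type and the positions on the phenyl differ. Against the 2-methylphenyl of compound 1, 3,4-difluorophenyl gives a 6.4-fold lower number from compound 1 to compound 3 (0.80 log units; beyond the scatter), the same direction as a 5.6-fold lower number from compound 1 to compound 2 (0.75 log units; beyond the scatter), so in these three compounds only compound 1 stands apart. No measurement is available that accounts for any of these results.

Whether halogen on this phenyl is needed at all remains open, as the series shown holds neither unsubstituted phenyl nor a phenyl carrying an amine or a carboxylic acid. Also open, on these data alone, is whether a saturated ring such as cyclohexyl could take the place of the phenyl on this nitrogen.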